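The compounds below may be only part of what the source reports. "The series", "measured", "known", "first", "only" and "open" are said of these compounds alone.

Measured so far in a functional assay on CHO-K1 cells for antagonist activity at transient receptor potential cation channel subfamily V member 1 (Homo sapiens), read by FLIPR; a higher number here means a weaker inhibitor, a lower number a stronger inhibitor:
compound 1 `Cc1ccc(CC2CCN(c3nc(C(F)(F)F)ccc3CNC(=O)C(C)c3ccc(NS(C)(=O)=O)c(F)c3)CC2)cc1`: 0.2 nM
compound 2 `CC(C(=O)NCc1ccc(C(F)(F)F)nc1N1CCC(Cc2ccc(F)c(F)c2)CC1)c1ccc(NS(C)(=O)=O)c(F)c1`: 0.2 nM
compound 3 `CC(C(=O)NCc1ccc(C(F)(F)F)nc1N1CCC(Cc2cc(F)cc(F)c2)CC1)c1ccc(NS(C)(=O)=O)c(F)c1`: 0.4 nM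

Compound 3 holds the largest of the three numbers, but a 2.0-fold higher number from compound 1 to compound 3 (0.30 log units; within the scatter) and a 2.0-fold higher number from compound 2 to compound 3 (0.30 log units; within the scatter) are both within the scatter, so the three compounds are not separated by this assay. Compound 4 `CC(C(=O)NCc1ccc(C(F)(F)F)nc1N1CCC(C(=O)c2ccc(F)cc2)CC1)c1ccc(NS(C)(=O)=O)c(F)c1` differs from compound 3 by (4-fluorophenyl)carbonyl in place of 3,5-difluorobenzyl on a saturated ring carbon. The steps seen so far, no change at the digits printed from compound 1 to compound 2 (within the scatter), a 2.0-fold higher number from compound 1 to compound 3 (0.30 log units; within the scatter) and a 2.0-fold higher number from compound 2 to compound 3 (0.30 log units; within the scatter), only swap substituents on the aromatic ring while the saturated chain carbon stays; none exchanges that carbon for a carbonyl, so they bear on compound 4 only loosely and show that ring substitution is tolerated. A modest step, a 2.5-fold higher number from compound 3 to compound 4 (0.40 log units; beyond the scatter), is expected here. For compound 4 the estimate is 1 nM, within 0.3 nM to 4 nM.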

Compound 4, inhibition constant: 3.9 nM
Compound 4: the middle estimate sits 3.9-fold (0.59 log units) below what was measured; the measured number falls inside the stated range.
By their numbers in this assay, from the lowest: compounds 1, 2 and 3 (each within the scatter of the next); then compound 4.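

Unlike the ring substitution swaps among compound 1, compound 2 and compound 3, replacing the benzyl groups on this saturated ring carbon with (4-fluorophenyl)carbonyl moves the number in this assay beyond the scatter: a 9.8-fold higher number from compound 3 to compound 4 (0.99 log units; beyond the scatter), a 20-fold higher number from compound 2 to compound 4 (1.29 log units; beyond the scatter) and a 20-fold higher number from compound 1 to compound 4 (1.29 log units; beyond the scatter). This group change alters both the link and the fluorine pattern, so the two contributions cannot be separated. Nothing available explains the weaker inhibition. Open, as far as these compounds go, is whether 4-fluorobenzyl, or a hydroxyl-bearing carbon in place of the carbonyl, would return the number to the range of the benzyl compounds.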